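The source may hold more compounds than are shown below. What is called first, only, known or untested is meant among the compounds shown, and "the series" means these compounds.

Compound 1 `NC/C=C/CN(C[C@H]1Cc2ncccc2CN1)[C@H]1CCCc2cccnc21`: 37%
Compound 2 `CN(CCCCN(C[C@H]1Cc2ncccc2CN1)[C@H]1CCCc2cccnc21)C1CCC(F)(F)CC1`: 35%

Both values come from an ADME assay on microsomes from liver (Mus musculus) for metabolic stability, using NADPH, with a stated time of 10 min; a higher number here means that more of the compound is left, a lower number that less of the compound is left. Compound 2 gives 35% and stands level with compound 1 at 37%, since the two numbers lie within the usual scatter of each other. These two compounds differ in more than one place, so no measured single change is available as a guide.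

Compound 3 `c1cnc2c(c1)CN[C@@H](CN(CCCCNC1CCOCC1)[C@H]1CCCc3cccnc31)C2` keeps the shared core and replaces one end of the chain: a group of 7 heavy atoms (5 carbon, 1 nitrogen, 1 oxygen; one six-membered non-aromatic ring with 1 hetero atom) in place of a group of 10 heavy atoms (7 carbon, 1 nitrogen, 2 fluorine; one six-membered non-aromatic ring of carbon only), on a saturated chain carbon, four bonds along the chain from an amine nitrogen. The incoming (oxan-4-yl)amino group sits on a saturated chain carbon, four bonds along the chain from an amine nitrogen.

The step of a number 7 percentage points higher from compound 2 to compound 3 (within the scatter) is expected to be small, slightly upward and within the scatter. For compound 3 the estimated value is 42%, with an expected range of 25% to 60%.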

Compound 3, percent of the compound remaining: 35%
Compound 3: middle estimate off by 7 percentage points, on the high side; low and high end bracket the measured number.
By their numbers in this assay, from the lowest: compounds 2, 3 and 1 (each within the scatter of the next).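

In this assay, among these compounds, putting the (oxan-4-yl)amino group in place of the larger group with the fluorine-bearing carbon ring gives no change at the digits printed from compound 2 to compound 3 (within the scatter), the first reading of a change at this one place, on a saturated chain carbon, four bonds along the chain from an amine nitrogen. Setting 3-((oxan-4-yl)amino)propyl in place of 3-aminoprop-1-en-1-yl gives a number 2 percentage points lower from compound 1 to compound 3 (within the scatter), so neither step separates these compounds in this test. Nothing measured here explains these results.

Still open, from the compounds shown here alone, is whether a carboxylic acid at the end of the chain, or a longer chain, would shift the number beyond the scatter. The compounds shown also leave open which part of these molecules is being used up in the microsomes.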